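A few compounds are considered here, and "the series" means these few. Any claim that something is new, unique, unknown or untested is made for them only; others in the source may bear on it.

Measured so far in an ADME assay on Huh7.5.1 cells (Homo sapiens) for cytotoxicity, read by WST assay, with a stated time of 48 h; on this read-out lower numbers stand for higher toxicity in this test and higher numbers for lower toxicity in this test:

- compound 1 `Cc1c(-c2ccc(Cc3ccc(OCC(F)(F)F)cc3)cc2)[nH]c2cccc(F)c2c1=O`: > 5000 nM, a limit of the assay rather than a number.
- compound 2 `Cc1c(-c2ccc(Cc3ccc(S(=N)(=O)C(F)(F)F)cc3)cc2)[nH]c2cccc(F)c2c1=O`: > 10000 nM, likewise a limit.
- compound 3 `COc1ccc(Cc2ccc(-c3[nH]c4cccc(F)c4c(=O)c3C)cc2)cc1`: > 10000 nM, likewise a limit.

Compound 1 therefore stands only at a limit, namely (the limit of > 5000 nM in this assay, at which 1 of the 3 values shown sits), while the other two compounds sit at the limit of > 10000 nM in this assay, at which 2 of the 3 values shown sit. None of the three gave a true number, so the steps among them cannot be sized: a step that the two limits leave unreadable from compound 1 to compound 2, a step that the two limits leave unreadable from compound 1 to compound 3 and a step that the two limits leave unreadable from compound 2 to compound 3 are all unreadable. Going by the values given here, what the values do show is that no member of this small set was toxic to the cells within the concentration range tested.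

Compound 4 `Cc1c(-c2ccc(Cc3ccc(N4CCCCC4)cc3)cc2)[nH]c2cccc(F)c2c1=O` differs from compound 1 in one place: piperidin-1-yl in place of 2,2,2-trifluoroethoxy on an aromatic carbon. Among the compounds with values here, no measured step involves piperidin-1-yl, and the steps that do exist give no readable size, so there is no measured change to lean on beyond the fact that all three compounds stayed non-toxic up to their limits.

The expectation is therefore that compound 4 also shows no toxicity within the tested range, with an estimated value of 10000 nM, ranging from 4000 nM to 25000 nM. The corresponding step, a step that the limit leaves unreadable from compound 1 to compound 4, is expected to be none beyond the scatter.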

Compound 4, half-maximal cytotoxic concentration: > 10000 nM
Compound 4 was reported as a limit; the forecaster's own chance of this, stated with the estimate: 70%; the middle value lies on the limit itself.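

Compound 4, like compound 1, compound 2 and compound 3, gave only a limit in this assay, and the steps from those three to compound 4 cannot be read. The four compounds leave open at what concentration any of them would harm the cells, and whether swapping the group on that aromatic carbon shifts that concentration at all.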